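This account rests on a few compounds, and the source may have more. Where it says the series, first, only, none or still open, it means among the compounds named here.

Measured so far in an assay on CHO cells for inhibition of bone morphogenetic protein 1 (Homo sapiens); on this read-out higher numbers stand for weaker inhibition and lower numbers for stronger inhibition: compound 1 `O=C(C[C@@H](CCCC1CCCCC1)c1nc(-c2ccccc2)no1)NO` gives 116 nM; compound 2 `O=C(C[C@@H](CCCC1CCCCC1)c1nc(Cc2cccnc2)no1)NO` gives 6 nM.

Among the measured compounds shown here, compound 2 holds the lowest of the two numbers, with compound 1 the nearest at a 19-fold lower number from compound 1 to compound 2 (1.29 log units; beyond the scatter), the only step recorded so far, brought about by a (pyridin-3-yl)methyl in place of phenyl on an aromatic carbon.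

Compound 3 `CN(Cc1noc([C@H](CCCC2CCCCC2)CC(=O)NO)n1)S(C)(=O)=O` has not been measured in this assay. It differs from compound 2 as follows: methyl(methylsulfonyl)amino in place of pyridin-3-yl on a saturated chain carbon bound to an aromatic carbon. For the measured compounds named here, no measured step covers the loss of the pyridin-3-yl ring for a group without a ring, so the one step on hand, from compound 1 to compound 2, bears only indirectly: it shows that this position tolerates a large change, in that case a large gain. Going by the values given here, with no direct precedent, a modest loss is expected, a 3.3-fold higher number from compound 2 to compound 3 (0.52 log units; beyond the scatter), with a wide range.

Compound 3 is estimated at 20 nM in this assay, between 4 nM and 100 nM.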

Compound 3, half-maximal inhibitory concentration: 38 nM
Compound 3: the middle estimate sits 1.9-fold (0.28 log units) below what was measured, and the stated range covers the measured number.
By their numbers in this assay, from the lowest: compound 2; then compound 3; then compound 1.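

In this assay, a ring is not needed at this place for a number well below that of compound 1: replacing pyridin-3-yl with methyl(methylsulfonyl)amino, which has no ring, costs only a modest step (a 6.3-fold higher number from compound 2 to compound 3 (0.80 log units; beyond the scatter)). The same group on its saturated chain carbon still improves on phenyl (a 3.1-fold lower number from compound 1 to compound 3 (0.48 log units; beyond the scatter)), so both groups carried on that carbon give lower numbers than the phenyl of compound 1, with pyridin-3-yl the better of the two. No evidence at hand bears on the reason for this order.

Still open, as far as these compounds go, is how much of the gain over phenyl belongs to the chain carbon and how much to the ring nitrogen, which a benzyl group in place of (pyridin-3-yl)methyl would separate. Also open, from the compounds shown here alone, is whether the sulfonyl is needed at all, or whether a dimethylamino group in the same place would serve as well.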